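Title: Varying the phenyl on the triazole of a salicylanilide

A few compounds are considered here, and "the series" means these few. Any claim that something is new, unique, unknown or untested is made for them only; others in the source may bear on it.

Measured so far:
compound 1, `COc1ccccc1-c1cn(-c2ccc(O)c(C(=O)Nc3cccc(C(F)(F)F)c3)c2)nn1`, 61%
compound 2, `COc1ccc(-c2cn(-c3ccc(O)c(C(=O)Nc4cccc(C(F)(F)F)c4)c3)nn2)cc1`, 9%

In a functional assay on HCT-116 cells (Homo sapiens) for inhibition, read by MTT assay, with a stated time of 2 days, tested at 10 uM (a higher number here means more inhibition at the concentration tested (going by the name of the read-out), a lower number less inhibition), compound 2 gives 9%, the lowest of the two numbers at hand; the nearest is compound 1 with 61%. For the measured compounds named here, the only measured step, a number 52 percentage points lower from compound 1 to compound 2 (beyond the scatter), is large and beyond the scatter, so moving the methoxy group around the phenyl ring on the five-membered ring has a strong effect within these compounds. Compound 3, `O=C(Nc1cccc(C(F)(F)F)c1)c1cc(-n2cc(-c3cccc(O)c3)nn2)ccc1O`, has not yet been tested. It differs from compound 2 in one place: 3-hydroxyphenyl in place of 4-methoxyphenyl on an aromatic carbon. Going by the values given here, no measured pair covers a hydroxy group on that ring, so the step from compound 1 to compound 2 bears on the question only by showing that the number in this assay is much lower for one placement of the methoxy group than for the other. Compound 3 is therefore expected to rise somewhat in this assay, by a number 16 percentage points higher from compound 2 to compound 3 (beyond the scatter), but with wide uncertainty. The estimate for compound 3 in this assay is 25%, spanning 5% to 55%.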

Compound 3, a percentage reported as inhibition, at one concentration (the size of the read-out at that concentration, not a potency): 25%
The estimate for compound 3 equals the measured number at the digits printed; measured number inside the range.
By their numbers in this assay, from the lowest: compound 2; then compound 3; then compound 1.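

In this assay, the 3-hydroxyphenyl group on this aromatic carbon of the five-membered ring gives a third level of inhibition, with a number 16 percentage points higher from compound 2 to compound 3 (beyond the scatter) and a number 36 percentage points lower from compound 1 to compound 3 (beyond the scatter). The position is therefore not limited to the two extremes set by the methoxyphenyl isomers: a phenyl group carrying a hydrogen-bond donor recovers part of the inhibition lost with 4-methoxyphenyl, but it does not reach the level seen with 2-methoxyphenyl. Nothing measured beyond these inhibition numbers is available to explain the differences.

Each step to compound 3 changes both the oxygen substituent and its place on the phenyl ring, so the compounds shown cannot separate the effect of having a hydroxy group rather than a methoxy group from the effect of where that group sits. On these data alone, it also remains open how an unsubstituted phenyl, or a phenyl ring bearing an amine or a carboxylic acid, would compare with these three compounds at this position.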